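The compounds below may be only part of what the source reports. "The series", "measured", "known", "first", "only" and "open" are said of these compounds alone.

Working notes on the series. The shared core carries a thiocarbonyl bearing morpholin-4-yl, and three analogues have been measured. Compound 1 `Cc1ccc2c(=O)c(CSC(=S)N3CCOCC3)coc2c1` gives 4000 nM in a functional assay on HEp-2 cells (Homo sapiens) for antiproliferative activity, read by MTT assay, with a stated time of 72 h; on this read-out higher numbers stand for weaker inhibition and lower numbers for stronger inhibition. Compound 2 `COc1ccc2occ(CSC(=S)N3CCOCC3)c(=O)c2c1` gives 4800 nM in this assay, and compound 3 `O=c1c(CSC(=S)N2CCOCC2)coc2ccccc12` gives 4400 nM in this assay. Compound 3 stands second highest of the three numbers; its nearest neighbour is compound 2 and its furthest is compound 1, and both gaps fall within the scatter, so the three compounds are indistinguishable on this read-out. The two single-point steps recorded so far, a 1.1-fold higher number from compound 1 to compound 3 (0.04 log units; within the scatter) and a 1.1-fold lower number from compound 2 to compound 3 (0.04 log units; within the scatter), both concern hydrogen in place of a substituent on an aromatic carbon, and neither rises above the scatter.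

The next compound, compound 4 `O=c1c(CSC(=S)N2CCCCC2)coc2ccccc12`, differs from compound 3 elsewhere: piperidin-1-yl in place of morpholin-4-yl on a thiocarbonyl carbon. Among the compounds with values here, no measured step touches the group on the thiocarbonyl carbon, so the two recorded steps say only that the aromatic variations have been flat; they carry no information on this exchange. With nothing in the series arguing for a move in either direction, compound 4 is expected to give 4200 nM in this assay, with a range from 1500 nM to 12000 nM. The step of a 1.0-fold lower number from compound 3 to compound 4 (0.02 log units; within the scatter) is accordingly estimated to lie within the scatter.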

Compound 4, half-maximal inhibitory concentration: 390 nM
Estimate against measurement, compound 4: 11-fold (1.03 log units) above, and the stated range ends above it.
By their numbers in this assay, from the lowest: compound 4; then compounds 1, 3 and 2 (each within the scatter of the next).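

Within the data shown here, the group on the thiocarbonyl carbon is the first place where a single exchange moves the number beyond the scatter: in this assay, piperidin-1-yl in place of morpholin-4-yl gives an 11-fold lower number from compound 3 to compound 4 (1.05 log units; beyond the scatter) while both recorded steps on an aromatic carbon stay within the scatter. The two groups are six-membered non-aromatic rings of 6 heavy atoms each, and they differ only in that morpholin-4-yl holds an oxygen where piperidin-1-yl holds a carbon, so this position responds strongly to a change confined to that one ring atom. The data offer no measurement that would explain the size of this step.

As far as these compounds go, the flat response to methyl and methoxy on an aromatic carbon is known only with morpholin-4-yl in place, so it remains open whether these substituents stay as silent with piperidin-1-yl. Also open, from the compounds shown here alone, is how far the gain extends to other groups on the thiocarbonyl carbon, such as pyrrolidin-1-yl, 4-methylpiperazin-1-yl or an open-chain diethylamino group.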